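The source may hold more compounds than are shown below. What is called first, only, known or untested is meant among the compounds shown, and "the series" means these compounds.

Compound 2, `CC(C)(C)OC(=O)N1CCC(O[C@H]2CC[C@H](Oc3cnc(S(C)(=O)=O)cn3)CC2)CC1`, is a full agonist in a functional assay on isolated protein for agonist activity at Glucose-dependent insulinotropic receptor (Homo sapiens), read by HTRF and cAMP accumulation (a higher number here means a larger maximal response, a lower number a smaller maximal response), where compound 2 gives 110%. The only companion so far is compound 1, `CC(C)(C)OC(=O)N1CCC(O[C@H]2CC[C@H](Oc3ccc(C#N)cc3)CC2)CC1`, which in this assay gives 116%. For the measured compounds named here, the single step joining them, a number 6 percentage points lower from compound 1 to compound 2 (within the scatter), exchanged the aromatic group on the oxygen and left the maximal response essentially unchanged, so the two numbers cannot be ranked against each other.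

Compound 3, `CC(C)S(=O)(=O)c1cnc(O[C@H]2CC[C@H](OC3CCN(C(=O)OC(C)(C)C)CC3)CC2)cn1`, differs from compound 2 at another site: isopropyl in place of methyl on a sulfonyl sulfur. The sulfonyl sulfur was not touched in any step seen so far, so there is no measured change that speaks directly to this isopropyl in place of methyl on a sulfonyl sulfur. Going by the values given here, the one known step, a number 6 percentage points lower from compound 1 to compound 2 (within the scatter), shows that a much larger swap elsewhere stayed within the scatter, and both compounds already reach a full response.

On that basis the step of a number 2 percentage points lower from compound 2 to compound 3 (within the scatter) is expected to stay within the scatter, and compound 3 is estimated at 108%, most likely between 92% and 122%.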

Compound 3, largest response reached (Emax), in percent of the reference or control that the assay uses: 109%
Compound 3: middle estimate off by 1 percentage points, on the low side; the range from low to high includes it.
By their numbers in this assay, from the lowest: compounds 3, 2 and 1 (each within the scatter of the next).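

For the compounds shown here, the swap of isopropyl in place of methyl on a sulfonyl sulfur gives the first reading at this position, and in this assay it appears as a number 1 percentage points lower from compound 2 to compound 3 (within the scatter) and no more than that. At this sulfur, then, methyl can give way to isopropyl without a difference that this read-out can resolve, and compound 3, at 109% in this measure, stands with compound 2 as a full agonist. No measurement at hand offers an explanation for this result.

On these data alone, what stays open is how far this tolerance extends at the sulfonyl sulfur, since only methyl and isopropyl have been seen there, and a single pair of compounds cannot define a trend. A cyclopropyl or a tert-butyl group on that sulfur would show whether other carbon groups behave the same way, while an amine or a carboxylic acid carried on a longer chain would test whether the full response survives a very different kind of group.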